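Isopropyl in Place of Methoxyethyl on a Sulfonamide Nitrogen

This account rests on a few compounds, and the source may have more. Where it says the series, first, only, none or still open, it means among the compounds named here.

Measured compounds:
Compound 1, `COCCN(C)S(=O)(=O)c1ccc(C)c(C#Cc2cc(Cl)ccc2OCC(=O)O)c1`: 0.006
Compound 2, `CC(C)c1ccc(S(C)(=O)=O)cc1C#Cc1cc(Cl)ccc1OCC(=O)O`: 0.003

In an ADME assay on a cell-free system (plasma, Homo sapiens) (on this read-out higher numbers stand for a larger free fraction and lower numbers for a smaller free fraction), compound 1 gives 0.006, and compound 2 gives 0.003. These two numbers lie within the usual scatter of each other, so they cannot be told apart. Compound 3, `Cc1ccc(S(=O)(=O)N(C)C(C)C)cc1C#Cc1cc(Cl)ccc1OCC(=O)O`, has not yet been measured in this assay. It differs from compound 1 in one place: isopropyl in place of 2-methoxyethyl on a sulfonamide nitrogen. Among the compounds with values here, no measured pair shows this change, so a small downward step is expected, a 1.5-fold lower number from compound 1 to compound 3 (0.18 log units; within the scatter), not clearly beyond the scatter. Compound 3 is expected to give 0.004, with a range of 0.002 to 0.008.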

Compound 3, unbound fraction: 0.002
Estimate against measurement, compound 3: 2.0-fold (0.30 log units) above; measured number inside the range.
By their numbers in this assay, from the lowest: compounds 3, 2 and 1 (each within the scatter of the next, the first and the last beyond it).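

In this assay there is a 3.0-fold lower number from compound 1 to compound 3 (0.48 log units; beyond the scatter) when isopropyl replaces 2-methoxyethyl on the sulfonamide nitrogen. Within the data shown here, this is the first readable step at this position, and it shows that the free fraction responds to a swap in which the group leaving carries one hydrogen-bond acceptor and the group entering carries none. No evidence on the cause is at hand.

This single pair cannot show whether the step holds on another core. As far as these compounds go, how a hydroxyethyl group or a dimethylaminoethyl chain would read at this nitrogen also remains open.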